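The source may hold more compounds than are shown below. What is called first, only, known or untested is meant among the compounds shown, and "the series" means these compounds.

Two measured compounds share one saturated core. Compound 1, `C[C@]1(c2ccccc2)OC[C@H]([C@@H]2CCCCN2)O1`, gives 847 nM in a functional assay (brain) for displacement of a labelled ligand, with Rattus norvegicus as the target; a higher number here means a weaker inhibitor, a lower number a stronger inhibitor. Compound 2, `CC[C@]1(c2cccs2)OC[C@H]([C@@H]2CCCCN2)O1`, gives 205 nM in this assay, the lower of the two numbers, and the gap up to compound 1 lies beyond the scatter. Since the two differ at two places at once, nothing can be said about either change on its own; only the two values stand.

Compound 3, `CC[C@]1(c2ccsc2)OC[C@H]([C@@H]2CCCCN2)O1`, carries the change thiophen-3-yl in place of thiophen-2-yl on a saturated ring carbon on compound 2. Within the data shown here, the data hold no measured pair that isolates this kind of change, so there is no reference step to lean on. A step of this kind, a rearrangement within the same group, is expected to stay small, of the order of a 1.7-fold higher number from compound 2 to compound 3 (0.23 log units; within the scatter), with no direction that the data support. For compound 3 the expected inhibition constant is 350 nM, within a range of 120 nM to 1000 nM.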

Compound 3, inhibition constant: 124 nM
Compound 3: the middle estimate sits 2.8-fold (0.45 log units) above what was measured, within the range that was stated.
By their numbers in this assay, from the lowest: compounds 3 and 2 (each within the scatter of the next); then compound 1.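

This pair gives the series its first step at a single place: in this assay, thiophen-3-yl in place of thiophen-2-yl on the saturated ring carbon gives a 1.7-fold lower number from compound 2 to compound 3 (0.22 log units; within the scatter) and leaves the two values indistinguishable. At this carbon, between two ring oxygen atoms, the attachment point of the thiophene can therefore differ without a change that stands clear of the scatter, at least for compound 2 and compound 3. No supporting measurement bears on this step.

The phenyl group of compound 1 remains the only other aryl group shown at this carbon, and it comes with a second difference, so its effect cannot be separated. From the compounds shown here alone, whether a pyridin-3-yl group on this carbon, or an N-methyl group on the piperidin-2-yl nitrogen, would shift the number beyond the scatter remains open.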